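Series notes: ethoxycarbonyl in place of fluoro on the aryl

The compounds below may be only part of what the source reports. "The series", "measured", "known", "first", "only" and "open" are said of these compounds alone.

Values in a functional assay on RPMI-8226 cells (Homo sapiens) for inhibition; a lower number here means a stronger inhibitor, a higher number a weaker inhibitor:
compound 1 `CCOC(=O)CNC(=O)N1CC1C#N`: 25000 nM
compound 2 `N#CC1CN1C(=O)Nc1ccc(F)cc1`: 5000 nM
compound 3 `CC(C)(C)NC(=O)N1CC1C#N`: 120000 nM

Compound 2 holds the lowest of the three numbers in this assay. Compound 1, with its ethoxycarbonylmethyl urea, stands higher, beyond the scatter; compound 3, with its tert-butyl urea, is furthest away, also beyond the scatter. Among the compounds with values here, the only aryl urea among the three is thus the one with the lowest number, but with a single example of that kind no pattern can be drawn from this.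

Compound 4 `CCOC(=O)c1ccc(NC(=O)N2CC2C#N)cc1` keeps the shared core of compound 2 and changes only the aromatic substituent: ethoxycarbonyl in place of fluoro on an aromatic carbon. Within the data shown here, no measured pair shows the effect of an ethoxycarbonyl group on the aromatic ring, so the step has to be guessed. The expectation is for a step within the scatter, perhaps a slight improvement, and the step estimated is a 1.3-fold lower number from compound 2 to compound 4 (0.10 log units; within the scatter). For compound 4 the value expected in this assay is 4000 nM, within a range of 800 nM to 20000 nM.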

Compound 4, half-maximal inhibitory concentration: 3000 nM
Estimate against measurement, compound 4: 1.3-fold (0.12 log units) above; low and high end bracket the measured number.
By their numbers in this assay, from the lowest: compounds 4 and 2 (each within the scatter of the next); then compound 1; then compound 3.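

In this assay, ethoxycarbonyl in place of fluoro on this aromatic carbon, para to a group of 8 heavy atoms, gives a 1.7-fold lower number from compound 2 to compound 4 (0.22 log units; within the scatter) and so leaves the two values within the scatter of each other. Within the data shown here, this is the only pair here that differs in one place, and it shows that the position can carry a group of 5 heavy atoms, with 2 hydrogen-bond acceptors and a double bond outside the aromatic ring, instead of a single fluorine without a shift beyond the scatter. No measurement at hand explains why these two substituents read alike.

As far as these compounds go, one pair cannot show whether this holds for the position in general, so the outcome with a carboxylic acid, an amine or a longer alkyl ester on the same aromatic carbon remains open. Also open, from the compounds shown here alone, is how a plain hydrogen at this carbon would compare with fluoro and ethoxycarbonyl, and whether either substituent would read the same on another carbon of the aromatic ring.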